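Adding a third methoxy group to a ring already capped

This account rests on a few compounds, and the source may have more. Where it says the series, first, only, none or still open, it means among the compounds named here.

Measured so far:
Compound 1 `COc1cc(/C=N/NC(=O)c2no[n+]([O-])c2C)ccc1O` gives in an ADME assay on J774.1 cells (Mus musculus) for cytotoxicity, read by MTT assay, with a stated time of 48 h (on this read-out lower numbers stand for stronger inhibition and higher numbers for weaker inhibition), a value of > 400000 nM.
Compound 2 `COc1ccc(/C=N/NC(=O)c2no[n+]([O-])c2C)cc1OC` gives in this assay a value of > 400000 nM.
Compound 3 `COc1ccc(/C=N/NC(=O)c2no[n+]([O-])c2C)cc1O` gives in this assay a value of > 400000 nM.

Each of these values is a limit of the assay, not a number. Compound 2 stands at the limit of > 400000 nM in this assay, at which 3 of the 3 values shown sit, and the same holds for compound 1 and for compound 3. For that reason the two single-point changes among them say nothing about size: the step that the two limits leave unreadable from compound 1 to compound 2 and the step that the two limits leave unreadable from compound 2 to compound 3 both stay unreadable.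

Compound 4 `COc1cc(/C=N/NC(=O)c2no[n+]([O-])c2C)cc(OC)c1OC` differs from compound 2 by methoxy in place of hydrogen on an aromatic carbon. Among the measured compounds shown here, both steps that bear on this change are unreadable, so no direction and no size can be taken from them; the only guide is that every measured compound sits at the same limit. Compound 4 is therefore expected to give 400000 nM, in a range from 150000 nM to 1000000 nM, most probably reported again only as a limit. The step this estimate implies, a number no higher from compound 2 to compound 4 (the limit leaves the size open), is expected to be none beyond the scatter.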

Compound 4, half-maximal inhibitory concentration: > 300000 nM
Compound 4: no number, only a limit (the forecaster's own chance of this, stated with the estimate: 85%); the middle value is on the limit's open side.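

In this assay compound 4 gives > 300000 nM, which is a limit and not a number. Compound 2 also stands only at a limit, so no step can be read between compound 2 and compound 4. The compounds shown leave open what true value any of them has, and whether the added methoxy group changes it at all.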